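The source may report more compounds than this note shows. Statements on the series, on what has been measured and on what is new or still open speak of the compounds shown alone.

Of the compounds shown here, two with a shared core have been measured so far in a functional assay on SF-268 cells (Homo sapiens) for inhibition; on this read-out higher numbers stand for weaker inhibition of growth and lower numbers for stronger inhibition of growth. Compound 1 (`NC(=O)c1cc(Cl)ccc1NC(=O)COc1ccccc1`) gives 9890 nM with a chloro group, while compound 2 (`NC(=O)c1cc(I)ccc1NC(=O)COc1ccccc1`) gives 934 nM with an iodo group. That makes compound 2 the lower of the two numbers, and so the stronger inhibitor of growth.

Compound 3 (`COc1ccc(NC(=O)COc2ccccc2)c(C(N)=O)c1`) has methoxy in place of iodo on an aromatic carbon. For the measured compounds named here, the only measured step that bears on this change, seen with iodo in place of chloro, is the large one of an 11-fold lower number from compound 1 to compound 2 (1.02 log units; beyond the scatter) and it lies beyond the scatter. Going by the values given here, no compound with a methoxy group has been measured, so that step offers only an indirect guide. With iodo gone, the number is expected to move back up toward the value of compound 1 (9890 nM), though perhaps not all the way. The estimated change is a 4.3-fold higher number from compound 2 to compound 3 (0.63 log units; beyond the scatter) and it is expected to be somewhat smaller than the measured step. Compound 3 is estimated at 4000 nM (expected range 1300 nM to 12000 nM).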

Compound 3, concentration for 50% growth inhibition: 2420 nM
Beside the measured number, compound 3's estimate is 1.7-fold (0.22 log units) above it; the range from low to high includes it.
By their numbers in this assay, from the lowest: compound 2; then compound 3; then compound 1.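

In this assay, a third group at this position shows that the change is not simply a two-way contrast between chloro and iodo: methoxy gives a number inside the span set by those two groups. Replacing iodo with methoxy gives a 2.6-fold higher number from compound 2 to compound 3 (0.41 log units; beyond the scatter), while the comparison with chloro gives a 4.1-fold lower number from compound 1 to compound 3 (0.61 log units; beyond the scatter), so methoxy keeps part of the advantage that iodo has over chloro. This also shows that a group other than a halogen, and one that brings a hydrogen-bond acceptor where iodo and chloro have none, can give a lower number than chloro at this place, although nothing available explains the order of the three groups.

The compounds shown leave open where bromo would fall among these groups, and whether ethoxy, as a longer chain, would keep or lose the standing of methoxy. They also leave open how an amine or a hydroxy group at this same position would compare, and whether the order of iodo, methoxy and chloro would hold on the other parts of the shared core.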